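This account rests on a few compounds, and the source may have more. Where it says the series, first, only, none or still open, it means among the compounds named here.

Three close relatives of a shared core have been tested, and a fourth awaits its number. Compound 1 `Fc1ccc2nc(-n3ccnn3)n(C3CC3)c2c1`, compound 2 `Fc1ccc2nc(-c3cn[nH]c3)n(C3CC3)c2c1` and compound 3 `Fc1ccc2nc(-c3cncs3)n(C3CC3)c2c1` differ only in the small aromatic ring attached to the core. In an assay on cells for inhibition of cytochrome P450 11B2, mitochondrial (Homo sapiens), read by HPLC, with a stated time of 90 min (a higher number here means a weaker inhibitor, a lower number a stronger inhibitor), compound 1 gives 1060 nM, compound 2 gives 782 nM and compound 3 gives 62 nM. Compound 2 therefore sits second highest of the three numbers: it is close to compound 1, with a 1.4-fold lower number from compound 1 to compound 2 (0.13 log units; within the scatter), and far from compound 3, with a 13-fold lower number from compound 2 to compound 3 (1.10 log units; beyond the scatter).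

The new compound 4 `Fc1ccc2nc(-c3cnccn3)n(C3CC3)c2c1` changes that same ring once more: pyrazin-2-yl in place of 1H-pyrazol-4-yl on an aromatic carbon. Among the compounds with values here, the steps that bear on this are the two swaps of the attached ring already measured. Exchanging one five-membered ring for another with a similar pattern, as in a 1.4-fold lower number from compound 1 to compound 2 (0.13 log units; within the scatter), changed little, while moving to the 1,3-thiazol-5-yl ring, as in a 17-fold lower number from compound 1 to compound 3 (1.23 log units; beyond the scatter) and a 13-fold lower number from compound 2 to compound 3 (1.10 log units; beyond the scatter), brought a large gain. Pyrazin-2-yl is a different case again, a six-membered ring with two acceptors and no donor, and nothing measured here matches it exactly. A moderate improvement is expected, in line with a 2.2-fold lower number from compound 2 to compound 4 (0.35 log units; beyond the scatter). For compound 4 the estimated value in this assay is 350 nM, most likely between 80 nM and 1500 nM.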

Compound 4, half-maximal inhibitory concentration: 541 nM
Compound 4: middle estimate off by 1.5-fold (0.19 log units), on the low side, within the range that was stated.
By their numbers in this assay, from the lowest: compound 3; then compounds 4, 2 and 1 (each within the scatter of the next).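

On an aromatic carbon between two ring nitrogen atoms, replacing a five-membered ring that has a hydrogen-bond donor with a six-membered ring that has none makes no clear difference in this assay, with a 1.4-fold lower number from compound 2 to compound 4 (0.16 log units; within the scatter) and, against the other five-membered ring, a 2.0-fold lower number from compound 1 to compound 4 (0.29 log units; within the scatter), so compounds 1, 2 and 4 cannot be told apart by a single step. The step to the remaining ring, an 8.7-fold higher number from compound 3 to compound 4 (0.94 log units; beyond the scatter), shows that the larger ring does not share the advantage of the 1,3-thiazol-5-yl ring, and compound 3 alone now stands beyond the scatter from each of the other three compounds. Nothing available explains why that ring stands apart.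

The compounds shown leave open whether the advantage of compound 3 depends on the sulfur atom of its ring, a question that a thiophen-2-yl or an oxazol-5-yl ring at the same place could address. They also leave open whether an added amine or methyl group on the pyrazin-2-yl ring of compound 4 would bring its number closer to that of compound 3.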